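Pyridin-4-yl in Place of an Aryl Group: Efficacy Outlook

The source may report more compounds than this note shows. Statements on the series, on what has been measured and on what is new or still open speak of the compounds shown alone.

Measured so far in an in vitro functional assay on HEK285-7 cells for antagonist activity at prostaglandin D2 receptor 2 (Homo sapiens), read by BRET and beta-arrestin recruitment; on this read-out higher numbers stand for larger maximal responses and lower numbers for smaller maximal responses:
- compound 1, `O=C(O)Cc1sc(C(c2ccc(F)cc2)c2ccc(F)cc2)nc1-c1ccccc1`, gives 80%
- compound 2, `N#Cc1cc(-c2nc(C(c3ccc(F)cc3)c3ccc(F)cc3)sc2CC(=O)O)ccc1F`, gives 80%

Among the measured compounds shown here, compound 2 stands level with compound 1 on these numbers; the only measured step, no change at the digits printed from compound 1 to compound 2 (within the scatter), did not move the maximal response beyond the usual scatter, even though it exchanged a plain phenyl for a 3-cyano-4-fluorophenyl at the same position that is now in question.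

Compound 3, `O=C(O)Cc1sc(C(c2ccc(F)cc2)c2ccc(F)cc2)nc1-c1ccncc1`, differs from compound 2 as follows: pyridin-4-yl in place of 3-cyano-4-fluorophenyl on an aromatic carbon. The change again sits on the aromatic carbon of the five-membered aromatic ring with 1 nitrogen and 1 sulfur, next to the ring nitrogen, with a smaller six-membered ring that carries one nitrogen in place of the carbon-only ring bearing a nitrile and a fluorine.

For the measured compounds named here, the one step that bears on this, from compound 1 to compound 2, was flat within the scatter. A step of about the same size, none beyond the scatter, is therefore expected: no change at the digits printed from compound 2 to compound 3 (within the scatter). Compound 3 is estimated to give 80% in this assay, with a range from 65% to 92%.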

Compound 3, largest response reached (reported as efficacy), in percent of the reference or control that the assay uses: 80%
Beside the measured number, compound 3's estimate shows no gap at the digits printed; the range from low to high includes it.
By their numbers in this assay, from the lowest: compounds 1, 2 and 3 (each within the scatter of the next).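

In this assay, pyridin-4-yl in place of 3-cyano-4-fluorophenyl gave no change at the digits printed from compound 2 to compound 3 (within the scatter), and pyridin-4-yl in place of phenyl gave no change at the digits printed from compound 1 to compound 3 (within the scatter). The earlier pair showed only carbon-only rings at this aromatic carbon, whereas the new result extends the flat picture to a smaller six-membered aromatic ring with a ring nitrogen, so the three groups tested here cannot be told apart by maximal response. No measurement shown explains this lack of separation.

As far as these compounds go, all three groups at this position are six-membered aromatic rings, so it remains open whether the maximal response would hold with a small alkyl group such as methyl, a saturated ring such as morpholine, or a simple amine at the same carbon. From the compounds shown here alone, it is equally open whether this flat behaviour depends on the rest of the molecule, for example if an amide took the place of the carboxymethyl group, and these numbers say nothing about how much of each compound is needed to reach that response.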